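The compounds below may be only part of what the source reports. "The series", "measured", "known", "first", "only" and "open" are said of these compounds alone.

Read-outs from a functional assay on A549 cells (Homo sapiens) for inhibition (a lower number here means a stronger inhibitor, a higher number a weaker inhibitor), so far:

- Compound 1 (`CC(C)c1cc(-c2n[nH]c(=O)n2-c2cccc(C(=O)NCCCCCC(=O)NO)c2)c(O)cc1O`) gives 4600 nM
- Compound 2 (`CC(C)c1cc(-c2n[nH]c(=O)n2-c2cccc(NC(=O)CCCCCC(=O)NO)c2)c(O)cc1O`) gives 1600 nM
- Compound 3 (`CC(C)c1cc(-c2n[nH]c(=O)n2-c2ccc(C(=O)NCCCCCCC(=O)NO)cc2)c(O)cc1O`) gives 4600 nM

Compound 3 stands level with compound 1, together the highest number of the three, while compound 2 reads lower (1600 nM), beyond the scatter. Next is compound 4 (`CC(C)c1cc(-c2n[nH]c(=O)n2-c2ccc(C(=O)NCCCCC(=O)NO)cc2)c(O)cc1O`), which carries hydroxycarbamoyl in place of 2-(hydroxycarbamoyl)ethyl on a saturated chain carbon, four bonds along the chain from an amide-type nitrogen. Among the measured compounds shown here, no measured pair isolates this change, so the expectation starts from compound 3 alone (4600 nM). In this assay a small move to a higher number is expected, and the estimated step is modest (a 1.3-fold higher number from compound 3 to compound 4 (0.12 log units; within the scatter)). The estimate for compound 4 is 6000 nM (expected range 2500 nM to 15000 nM).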

Compound 4, half-maximal inhibitory concentration: 4600 nM
Estimate against measurement, compound 4: 1.3-fold (0.12 log units) above, and the stated range covers the measured number.
By their numbers in this assay, from the lowest: compound 2; then compounds 1, 3 and 4 (each within the scatter of the next).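

In this assay, hydroxycarbamoyl in place of 2-(hydroxycarbamoyl)ethyl, on a saturated chain carbon four bonds along the chain from an amide-type nitrogen, gives no change at the digits printed from compound 3 to compound 4 (within the scatter) as its first isolated step. Among the compounds shown here, at this place, then, the shorter chain end reads the same as the longer one, a result that no earlier single-place pair could show. Nothing available accounts for this flat step.

Going by these compounds, how a carboxylic acid in place of hydroxycarbamoyl would read at this place remains open. A chain end shorter or longer than these two is also untested by this one step.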